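Removing a Silyl Group from a Tetrahydropyran Ester

The source may report more compounds than this note shows. Statements on the series, on what has been measured and on what is new or still open speak of the compounds shown alone.

Compound 1, `CC(C)(C)[Si](C)(C)OC[C@H]1OCCC[C@H]1O[Si](C)(C)C(C)(C)C`: in a functional assay on WiDr cells (Homo sapiens) for antiproliferative activity, read by sulforhodamine B assay, with a stated time of 48 h (a lower number here means a stronger inhibitor of growth, a higher number a weaker inhibitor of growth), compound 1 gives > 100000 nM, a limit of the assay.
Compound 2, `CC(C)(C)[Si](C)(C)O[C@@H]1CCCO[C@@H]1CO`: compound 2 gives > 100000 nM, also a limit.
Compound 3, `CC(C)(C)[Si](C)(C)O[C@@H]1CCCO[C@@H]1CC(=O)OCc1ccccc1`: compound 3 gives 19000 nM.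

Compounds 1 and 2 differ by a hydrogen atom in place of a group of 7 heavy atoms (6 carbon, 1 silicon; no ring), on an oxygen on a saturated carbon. The step between them, a step that the two limits leave unreadable from compound 1 to compound 2, cannot be read because of the limit of > 100000 nM in this assay, at which 2 of the 3 values shown sit. Going by the values given here, compound 3 shares neither limit, giving the only number among the three; how its core differs from the core of compound 1 is not broken down here.

Compound 4, `O=C(C[C@H]1OCCC[C@H]1O)OCc1ccccc1`, has not been measured in this assay. It differs from compound 3 by a hydrogen atom in place of a group of 7 heavy atoms (6 carbon, 1 silicon; no ring), on an oxygen on a saturated carbon. This is the same kind of change as that from compound 1 to compound 2, though not the same: there the oxygen sat on a saturated carbon whose other neighbour was a saturated chain carbon, here the other neighbour is a saturated ring carbon.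

The expected step from compound 3 to compound 4 is a 2.6-fold higher number from compound 3 to compound 4 (0.42 log units; beyond the scatter), with little to rest on, since the earlier step of this kind is unreadable. Compound 4 is estimated at 50000 nM, within 10000 nM to 150000 nM.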

Compound 4, concentration for 50% growth inhibition: > 100000 nM
Compound 4 was reported as a limit; the forecaster's own chance of this, stated with the estimate: 50%; at least 2.0-fold (0.30 log units) between middle value and limit.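

On the core of compound 3, replacing the silyl group with a hydrogen atom gives an at least 5.2-fold higher number from compound 3 to compound 4 (0.72 log units; beyond the scatter) in this assay, so on this core, growth inhibition weakens when the group is lost. The value of compound 4, > 100000 nM, is a limit of the assay. This single readable step does not show that the change has the same effect on another core, since the same kind of change on the core of compound 1 cannot be read, because compound 1 and compound 2 both give limits: the limit of > 100000 nM in this assay, at which 3 of the 4 values shown sit.

The compounds shown carry only the silyl group or a hydrogen atom on this oxygen, so it remains open how a smaller group, such as a methyl ether or an acetate ester, would behave there. Also open, going by these compounds, is whether the benzyl ester shared by compound 3 and compound 4 could be replaced by a carboxylic acid or an amide.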